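Ester tail variants on the shared core: compound 4

The source may report more compounds than this note shows. Statements on the series, on what has been measured and on what is new or still open speak of the compounds shown alone.

In a functional assay on SK-BR-3 cells (Homo sapiens) for antiproliferative activity, read by MTT assay, with a stated time of 72 h (on this read-out lower numbers stand for stronger inhibition and higher numbers for weaker inhibition), compound 1 `C/C=C1/[C@H](O[C@@H]2O[C@H](CO)[C@@H](O)[C@H](O)[C@H]2O)OC=C(C(=O)OC)[C@H]1CC(=O)OCCCc1ccc(OC)c(OC)c1` gives > 20000 nM, which is a limit of the assay and not a number. Compound 2 `C/C=C1/[C@H](O[C@@H]2O[C@H](CO)[C@@H](O)[C@H](O)[C@H]2O)OC=C(C(=O)OC)[C@H]1CC(=O)OCCc1ccc(OC)c(OC)c1` gives > 15000 nM in this assay, again only a limit. Compound 3 `C/C=C1/[C@H](O[C@@H]2O[C@H](CO)[C@@H](O)[C@H](O)[C@H]2O)OC=C(C(=O)OC)[C@H]1CC(=O)OCc1ccc(OC)c(OC)c1` likewise reaches only a limit in this assay, > 15000 nM. Compound 3 therefore stands at a limit, as do the two other values shown: the limit of > 15000 nM in this assay, at which 2 of the 3 values shown sit, holds two of the three, the limit of > 20000 nM in this assay, at which 1 of the 3 values shown sits, holds the remaining one.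

The steps among the measured compounds, a step that the two limits leave unreadable from compound 1 to compound 2, a step that the two limits leave unreadable from compound 1 to compound 3 and a step that the two limits leave unreadable from compound 2 to compound 3, all run between limits, so none of their sizes can be read. Going from 2-(3,4-dimethoxyphenyl)ethyl through 3,4-dimethoxybenzyl to 3,4-dimethoxyphenyl on a saturated chain carbon bound to an oxygen next to a carbonyl group leaves every compound at a limit.

Compound 4 `C/C=C1/[C@H](O[C@@H]2O[C@H](CO)[C@@H](O)[C@H](O)[C@H]2O)OC=C(C(=O)OC)[C@H]1CC(=O)OCCc1ccc(O)cc1` differs from compound 3 by 4-hydroxybenzyl in place of 3,4-dimethoxyphenyl on a saturated chain carbon bound to an oxygen next to a carbonyl group. For the measured compounds named here, no measured step offers a readable size, and every compound shown sits at a limit, so no step beyond the scatter is expected; compound 4 is expected to remain at a limit in this assay as well. Compound 4 is estimated at 20000 nM, with a range of 8000 nM to 60000 nM. The expected step is a step that the limit leaves unreadable from compound 3 to compound 4.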

Compound 4, half-maximal inhibitory concentration: > 20000 nM
Compound 4: only a limit was reported; the forecaster's own chance of this, stated with the estimate: 80%; the middle value sits exactly at the limit.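

In this assay compound 4 gives > 20000 nM, a limit and not a number. Its steps to compound 1, compound 2 and compound 3 all run between limits, so none can be read. With all four compounds at limits, the compounds shown leave open how these ester tails on the shared core rank against one another in this assay.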